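From Dimethylphenyl to Methoxyphenyl on the Sulfonamide

The source may hold more compounds than are shown below. What is called first, only, known or untested is meant among the compounds shown, and "the series" means these compounds.

In a functional assay on MCF7 cells (Homo sapiens) for antiproliferative activity, read by sulforhodamine B assay, with a stated time of 48 h (a higher number here means a weaker inhibitor, a lower number a stronger inhibitor), compound 1 `Cc1cccc(NS(=O)(=O)c2ccc(N3CCNC3=O)cc2)c1` gives 190 nM, while compound 2 `Cc1ccc(C)c(NS(=O)(=O)c2ccc(N3CCNC3=O)cc2)c1` gives 48 nM, the lower of the two numbers. Compound 3 `COc1ccccc1NS(=O)(=O)c1ccc(N2CCNC2=O)cc1` has 2-methoxyphenyl in place of 2,5-dimethylphenyl on a sulfonamide nitrogen. Among the compounds with values here, only one measured step bears on this change, a 4.0-fold lower number from compound 1 to compound 2 (0.60 log units; beyond the scatter), which is modest but beyond the scatter and concerns a methyl, not a methoxy group. Within the data shown here, a modest move to a higher number is therefore expected, with no measurement yet to confirm it. The expected change in this assay is a 2.7-fold higher number from compound 2 to compound 3 (0.43 log units; beyond the scatter). For compound 3 the estimate is 130 nM, with a range of 40 nM to 400 nM.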

Compound 3, half-maximal inhibitory concentration: 770 nM
The estimate for compound 3 lay 5.9-fold (0.77 log units) below the measured number; the measured number lies above the stated range.
By their numbers in this assay, from the lowest: compound 2; then compound 1; then compound 3.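

In this assay, within the data shown here, the change from 2,5-dimethylphenyl to 2-methoxyphenyl on the sulfonamide nitrogen gives a 16-fold higher number from compound 2 to compound 3 (1.21 log units; beyond the scatter) and is a large step, so this position is far more sensitive than the single methyl step suggested. The same group also gives a 4.1-fold higher number from compound 1 to compound 3 (0.61 log units; beyond the scatter) and so places compound 3 highest of the three, not between the two methyl-bearing compounds. Nothing available accounts for this loss. The compounds shown leave open whether the methoxy group itself or the absence of the methyl groups drives the rise, and how an ethoxy group or an amine on that ring would read.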